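This account rests on a few compounds, and the source may have more. Where it says the series, first, only, none or still open, it means among the compounds named here.

Working notes on the series built on the core of compound 1 (`O=C1/C(=C/c2ccc(F)cc2)Cc2ccccc21`). In a functional assay on CCRF-CEM cells (Homo sapiens) for inhibition (on this read-out higher numbers stand for weaker inhibition and lower numbers for stronger inhibition), compound 1 gives 42200 nM, and compound 2 (`O=C1/C(=C/c2cccc(Cl)c2)Cc2ccccc21`) gives 31800 nM. Compound 3 (`O=C1/C(=C/c2ccc(Cl)cc2)Cc2ccccc21`) gives 284000 nM, the highest number of the three and so the weakest inhibition, beyond the scatter from both others.

Next in view is compound 4 (`O=C1/C(=C/c2ccc(Br)cc2)Cc2ccccc21`), with this change: bromo in place of chloro on an aromatic carbon. In words, bromo in place of chloro on an aromatic carbon, para to a large group.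

Among the measured compounds shown here, one measured step bears on it, a swap of the same kind at the same place: a 6.7-fold higher number from compound 1 to compound 3 (0.83 log units; beyond the scatter). That step was modest but beyond the scatter, and a single step does not fix a trend across the halogens. Its direction alone would put compound 4 higher still. Against that, compound 3 at 284000 nM stands alone above the other two, so a modest move back toward lower numbers in this assay is expected, with real uncertainty about direction.

The estimated change is a 2.4-fold lower number from compound 3 to compound 4 (0.37 log units; beyond the scatter).

For compound 4 the expected value is 120000 nM, with an estimated range from 35000 nM to 350000 nM.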

Compound 4, half-maximal inhibitory concentration: 284000 nM
The estimate for compound 4 lay 2.4-fold (0.37 log units) below the measured number; the measured number falls inside the stated range.
By their numbers in this assay, from the lowest: compounds 2 and 1 (each within the scatter of the next); then compounds 3 and 4 (each within the scatter of the next).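

In this assay, bromo in place of chloro on this aromatic carbon, para to a large group, gives a flat result (no change at the digits printed from compound 3 to compound 4 (within the scatter)), so the halogen swap does not carry on in the direction of the step from fluoro to chloro (a 6.7-fold higher number from compound 1 to compound 3 (0.83 log units; beyond the scatter)). Going straight from fluoro to bromo at the same place gives a step of the same size (a 6.7-fold higher number from compound 1 to compound 4 (0.83 log units; beyond the scatter)), which leaves the fluoro compound apart, while the chloro and bromo compounds cannot be told apart in this read-out and form a single level among these three compounds. Nothing available gives a reason for this split between fluoro on one side and chloro and bromo on the other.

Open, as far as these compounds go, is whether that level holds for groups other than halogens at this place, such as methoxy, an amine or a carboxylic acid, or whether any of these returns the numbers toward that of compound 1. Also open is whether bromo or fluoro would follow the same pattern at the other ring position, where compound 2 carries its chloro and is the only example shown.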